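The source may hold more compounds than are shown below. What is called first, only, known or untested is meant among the compounds shown, and "the series" means these compounds.

Compound 1 `COc1ccc(-c2cc(/C=C/C(=O)c3ccc(N)cc3)[nH]n2)cc1` sits in the upper part of the three measured numbers. In a functional assay on SF-539 cells (Homo sapiens) for inhibition, read by sulforhodamine B assay, with a stated time of 48 h (on this read-out lower numbers stand for higher toxicity in this test and higher numbers for lower toxicity in this test), compound 1 gives 8250 nM. For the measured compounds named here, compound 2 `COc1ccc(C(=O)/C=C/c2cc(-c3cc(OC)c(OC)c(OC)c3)n[nH]2)cc1OC` gives 5310 nM in this assay, a number that lies within the scatter of the one for compound 1, so the two cannot be ordered. Compound 3 `COc1cc(-c2cc(/C=C/C(=O)c3ccc(F)c(F)c3)[nH]n2)cc(OC)c1OC` gives 70000 nM in this assay, and that gap to compound 1 goes beyond the scatter. The single one-place step among these three, a 13-fold higher number from compound 2 to compound 3 (1.12 log units; beyond the scatter), concerns the aryl on the carbonyl carbon and not the aryl on the shared core.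

Compound 4 `COc1ccc(-c2cc(/C=C/C(=O)c3ccc(N)cc3)[nH]n2)cc1OC` differs from compound 1 by methoxy in place of hydrogen on an aromatic carbon. Going by the values given here, no measured step touches this position, so nothing here shows a change beyond the scatter for it, and compound 4 is expected to sit close to compound 1 in this assay, with a 1.2-fold lower number from compound 1 to compound 4 (0.07 log units; within the scatter) as the expected step. Compound 4 is therefore estimated at 7000 nM, likely between 2500 nM and 20000 nM.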

Compound 4, concentration lethal to 50% of the cells: 7190 nM
Compound 4: the middle estimate sits 1.0-fold (0.01 log units) below what was measured; measured number inside the range.
By their numbers in this assay, from the lowest: compounds 2, 4 and 1 (each within the scatter of the next); then compound 3.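

In this assay, for the compounds shown here, methoxy in place of hydrogen on an aromatic carbon, ortho to a methoxy group and meta to a large group, gives the first measured step at this position (a 1.1-fold lower number from compound 1 to compound 4 (0.06 log units; within the scatter)), and it stays within the scatter. Going by these compounds alone, this position therefore takes a second methoxy with no difference that this test can resolve, whereas the only earlier one-place step (a 13-fold higher number from compound 2 to compound 3 (1.12 log units; beyond the scatter)) concerned the aryl on the carbonyl carbon. No supporting measurement is available to explain this result.

On these data alone, only hydrogen and methoxy are seen at this position, so it remains open whether a hydroxyl, a chlorine atom or an ethoxy group would also stay within the scatter. As far as these compounds go, it is also open whether the methoxy step would read the same with another aryl on the carbonyl carbon, such as the 3,4-difluorophenyl of compound 3.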